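A few compounds are considered here, and "the series" means these few. Any claim that something is new, unique, unknown or untested is made for them only; others in the source may bear on it.

Compound 1, with the structure `COc1ccccc1Oc1ccc2c(NCCCNCc3ccco3)ccnc2c1`, was tested in an ADME assay on HepG2 cells (Homo sapiens) for cytotoxicity, read by luminescence, CellTiter-Glo and ATP content, with a stated time of 72 h (a higher number here means that more compound is needed for the effect, a lower number that less compound is needed), where compound 1 gives 6500 nM. Among the two compounds measured, compound 1 stands at the highest of the two numbers. Its nearest neighbour is compound 2, with the structure `COc1ccc(F)cc1CNCCCNc1ccnc2cc(Cc3ccc(F)cc3)ccc12`; in this assay compound 2 gives 3530 nM, and the gap between compound 1 and compound 2 lies within the usual scatter of such measurements, so the two values cannot be told apart. Among the compounds with values here, no step between two measured compounds that differ in a single place is available from these data.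

Compound 3, with the structure `CC(C)(C)c1ccc(-c2ccc3c(NCCCNCc4ccco4)ccnc3c2)cc1`, has not yet been measured. Its structure differs from that of compound 1 by 4-(tert-butyl)phenyl in place of 2-methoxyphenoxy on an aromatic carbon. Within the data shown here, no measured pair shows the effect of this change, so the expectation rests on the single value of compound 1. For compound 3 a step of a 2.2-fold lower number from compound 1 to compound 3 (0.34 log units; beyond the scatter) is expected, toward a lower number and only modestly beyond the scatter. Compound 3 is thus estimated at 3000 nM, within a range from 1000 nM to 9000 nM.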

Compound 3, half-maximal effective concentration: 3150 nM
The estimate for compound 3 lay 1.1-fold (0.02 log units) below the measured number; measured number inside the range.
By their numbers in this assay, from the lowest: compounds 3, 2 and 1 (each within the scatter of the next, the first and the last beyond it).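

In this assay, within the data shown here, the exchange of 2-methoxyphenoxy for 4-(tert-butyl)phenyl on this aromatic carbon gives the first step that can be read between two compounds differing in one place: a 2.1-fold lower number from compound 1 to compound 3 (0.31 log units; beyond the scatter), a modest change that lies beyond the scatter. The change replaces a group of 9 heavy atoms with 2 hydrogen-bond acceptors by one of 10 heavy atoms with 0 hydrogen-bond acceptors, while a six-membered aromatic ring of carbon only is present in both, so this position is now seen to affect the number, though only modestly. No measurement shown here gives a reason for this step.

Among these compounds, the single pair leaves open how the number would respond to other groups at this position, such as an unsubstituted phenyl, a morpholine or a carboxylic acid, since one exchange cannot show a trend. Among the compounds shown here, it also leaves open whether the same exchange would give a step of similar size with a side chain other than the one shared by compound 1 and compound 3.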